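The compounds below may be only part of what the source reports. "The series", "measured", "known", "first", "only" and "open" are said of these compounds alone.

Three compounds of one family were tested in a functional assay on 786-0 cells (Homo sapiens) for cytotoxicity, read by sulforhodamine B assay, with a stated time of 48 h; a higher number here means a weaker inhibitor of growth, a lower number a stronger inhibitor of growth. Compound 1, `Nc1nc(Cl)c2ncn(Cc3ccc(CCl)cc3)c2n1`, gives 5250 nM. Compound 2, `ClCc1cccc(Cn2cnc3c(Cl)nc(Cl)nc32)c1`, gives 12300 nM. Compound 3, `ClCc1ccc(Cn2cnc3c(Cl)nc(Cl)nc32)cc1`, gives 14100 nM. The difference between the cores of compound 2 and compound 3 is not broken down here. From compound 3 to compound 1 a single change was made, (amino in place of chloro on an aromatic carbon), and it produced a 2.7-fold lower number from compound 3 to compound 1 (0.43 log units; beyond the scatter). Compound 4, `Nc1nc(Cl)c2ncn(Cc3cccc(CCl)c3)c2n1`, is not yet measured; it differs from compound 2 by amino in place of chloro on an aromatic carbon, the same change at the same place. Because compound 3 to compound 1 gave a 2.7-fold lower number from compound 3 to compound 1 (0.43 log units; beyond the scatter), a similar step is expected from compound 2 to compound 4 in this assay, namely a 2.6-fold lower number from compound 2 to compound 4 (0.41 log units; beyond the scatter). On that basis compound 4 is estimated to give 4800 nM, with a likely range from 2000 nM to 11000 nM. This rests on one earlier step only.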

Compound 4, concentration for 50% growth inhibition: 6600 nM
Compound 4: the middle estimate sits 1.4-fold (0.14 log units) below what was measured; measured number inside the range.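

In this assay, amino in place of chloro on an aromatic carbon gives a 1.9-fold lower number from compound 2 to compound 4 (0.27 log units; within the scatter), so on this core the step alone cannot be told apart from the ordinary spread of repeated measurements. Compared with the earlier step, its size does not differ measurably: the same change on two cores in this assay, a 2.7-fold lower number (0.43 log units; beyond the scatter) from compound 3 to compound 1 and a 1.9-fold lower number (0.27 log units; within the scatter) from compound 2 to compound 4, 1.4-fold (0.16 log units) apart, within the scatter of two such steps. The two results are compatible with the change carrying across these two cores, but two pairs cannot show that it would do so on any other core, or that the step on this core is real.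

The compounds shown leave open whether a methylamino or methoxy group on that same aromatic carbon would behave as amino does. They also leave open what a methyl or hydroxymethyl group would do in place of the chloromethyl group.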